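Adding a nitro group to compound 2

The compounds below may be only part of what the source reports. "The series", "measured", "known", "first", "only" and "open" are said of these compounds alone.

compound 1 `CC(=NNC(=S)Nc1cccc([N+](=O)[O-])c1)c1ccccn1`: 69 nM
compound 2 `C/C(=N/NC(=S)Nc1ccccc1)c1ccccn1`: 1.4 nM

In a functional assay on U-87MG ATCC cells (Homo sapiens) for cytotoxicity, read by MTT assay, with a stated time of 48 h (a lower number here means a stronger inhibitor, a higher number a weaker inhibitor), compound 2 gives 1.4 nM. That is the lower of the two numbers, and the gap up to compound 1 lies beyond the usual scatter. Compound 3 `C/C(=N/NC(=S)Nc1cccc([N+](=O)[O-])c1)c1ccccn1` is compound 2 with one change: nitro in place of hydrogen on an aromatic carbon, meta to a large group (nitro in place of hydrogen on an aromatic carbon). Within the data shown here, no pair of measured compounds shows this change alone. Still, compound 1 also carries a nitro group, and in this assay compound 1 gives 69 nM, so compound 3 is expected to land close to that number. The expected change is a 43-fold higher number from compound 2 to compound 3 (1.63 log units; beyond the scatter), a rise beyond the scatter towards weaker inhibition. For compound 3 the estimated value is 60 nM, with an expected range from 15 nM to 250 nM.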

Compound 3, half-maximal inhibitory concentration: 69 nM
Compound 3: the middle estimate sits 1.2-fold (0.06 log units) below what was measured, within the range that was stated.
By their numbers in this assay, from the lowest: compound 2; then compounds 1 and 3 (each within the scatter of the next).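

With this assay, the effect of this change can now be read on its own: nitro in place of hydrogen on an aromatic carbon, meta to a large group, gives a 49-fold higher number from compound 2 to compound 3 (1.69 log units; beyond the scatter), a large move towards weaker inhibition. Between the two nitro compounds there is no change at the digits printed from compound 1 to compound 3 (within the scatter), so whether the double bond is drawn with a configuration makes no visible difference to the number. These two compounds have the same atoms and bonds, and the only thing separating them is: the fact that one of compounds 1 and 3 is drawn with a defined configuration and the other without, at the place where they differ

Nitro is the only group shown at this position, so it remains open whether an amine, a methoxy group or a fluorine atom there would stay close to compound 2 or also move towards weaker inhibition. On these data alone, whether nitro at another carbon of the same ring would produce a step of similar size also remains open.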